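This account rests on a few compounds, and the source may have more. Where it says the series, first, only, none or still open, it means among the compounds named here.

Compound 1 `COc1ccc(N(C)c2ccnc(Cl)n2)cc1` gives 611 nM in a functional assay on A549 cells (Homo sapiens) for antiproliferative activity, read by MTT assay, with a stated time of 48 h; on this read-out lower numbers stand for stronger inhibition and higher numbers for weaker inhibition. Compound 2 `COc1ccc(N(C)c2ccnc(Cl)n2)cc1F` gives 651 nM in this assay. Compound 3 `COc1ccc(N(C)c2ccnc(Cl)n2)cc1OCCBr` gives 4640 nM in this assay, the highest number of the three and thus the weakest inhibition among them; the steps of a 7.6-fold higher number from compound 1 to compound 3 (0.88 log units; beyond the scatter) and a 7.1-fold higher number from compound 2 to compound 3 (0.85 log units; beyond the scatter) both mark that gap. Compound 4 `COc1ccc(N(C)c2ccnc(Cl)n2)cc1OCCCCC[Se]C#N` differs from compound 3 by a group of 6 heavy atoms (4 carbon, 1 nitrogen, 1 selenium; no ring) in place of one bromine atom, on a saturated chain carbon, two bonds along the chain from an oxygen on an aromatic ring. Among the compounds with values here, no measured step involves a group of this kind, so the only guide is that the 2-bromoethoxy chain itself raised the number modestly in a 7.6-fold higher number from compound 1 to compound 3 (0.88 log units; beyond the scatter); a further step of similar size, or none beyond the scatter, is plausible. The expected step is therefore modest and upward: a 1.5-fold higher number from compound 3 to compound 4 (0.18 log units; within the scatter). Compound 4 is estimated at 7000 nM, with a range from 2000 nM to 25000 nM.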

Compound 4, half-maximal inhibitory concentration: > 10000 nM
Compound 4 ended at the assay's limit; the forecaster's own chance of this, stated with the estimate: 10%; middle value at least 1.4-fold (0.15 log units) from the limit.
By their numbers in this assay, from the lowest: compounds 1 and 2 (each within the scatter of the next); then compound 3. At a limit, above all of these: compound 4.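

Compound 4 gives only a limit in this assay, not a number: the limit of > 10000 nM in this assay, at which 1 of the 4 values shown sits. Even so, the step can be read as an at least 2.1-fold higher number from compound 3 to compound 4 (0.33 log units; beyond the scatter), so this group on a saturated chain carbon gives weaker inhibition than bromo does. The earlier compounds shown here showed only that adding the 2-bromoethoxy chain weakened inhibition, and this change moves the number further in the same direction rather than recovering it. As far as these compounds go, how far compound 4 lies past its limit remains open. So does whether an amine or a carboxylic acid at this place would bring the number back down.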